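Sulfamoylamino for methanesulfonamido: expected cytotoxicity of compound 3

A few compounds are considered here, and "the series" means these few. Any claim that something is new, unique, unknown or untested is made for them only; others in the source may bear on it.

compound 1 `O=c1c(C2=CS(=O)(=O)c3cc(F)ccc3N2)c(O)c2cc(F)ccc2n1Cc1ccc(F)cc1`: > 50000 nM
compound 2 `CS(=O)(=O)Nc1ccc2c(c1)S(=O)(=O)C=C(c1c(O)c3cc(F)ccc3n(Cc3ccc(F)cc3)c1=O)N2`: > 50000 nM

In an ADME assay on 2209-23 cells (Homo sapiens) for cytotoxicity, read by WST assay (on this read-out lower numbers stand for higher toxicity in this test and higher numbers for lower toxicity in this test), compound 1 gives > 50000 nM, which is a limit of the assay and not a number. Compound 2 likewise gives > 50000 nM, again only a limit. The step that the two limits leave unreadable from compound 1 to compound 2 therefore cannot be read. Both values sit at the limit of > 50000 nM in this assay, at which 2 of the 2 values shown sit. Compound 3 `NS(=O)(=O)Nc1ccc2c(c1)S(=O)(=O)C=C(c1c(O)c3cc(F)ccc3n(Cc3ccc(F)cc3)c1=O)N2` differs from compound 2 by amino in place of methyl on a sulfonyl sulfur. No readable measured step bears on this change, and compound 2 already stands at the limit, so no step beyond the scatter is expected; the expected step is a step that the limit leaves unreadable from compound 2 to compound 3. Compound 3 is expected at 60000 nM, between 25000 nM and 200000 nM.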

Compound 3, half-maximal cytotoxic concentration: > 50000 nM
Compound 3 ended at the assay's limit; the forecaster's own chance of this, stated with the estimate: 85%; the middle value is on the limit's open side.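

No step can be read among compound 1, compound 2 and compound 3, since each gives only a limit and not a number: the limit of > 50000 nM in this assay, at which 3 of the 3 values shown sit.

Going by these compounds, how far each compound lies past that limit, and which of the three is the least toxic in this test, stays open.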